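The compounds below may be only part of what the source reports. "The series", "measured", "known", "first", "only" and "open" are said of these compounds alone.

Of the compounds shown here, two sharing a core have been measured in a functional assay on the whole organism for antagonist activity, with Rattus norvegicus as the target; on this read-out lower numbers stand for an effect already at smaller amounts and higher numbers for an effect only at larger amounts of compound. In that test compound 1 (`CN(C)C1CCN(C(=O)COc2cc(C(=O)N3CCCCc4sccc43)ccc2NC(=O)c2ccccc2-c2ccccc2)CC1`) gives 0.02 mg/kg, and compound 2 (`CCN(CC)C1CCN(C(=O)CCCOc2cc(C(=O)N3CCCCc4sccc43)ccc2NC(=O)c2ccccc2-c2ccccc2)CC1`) gives 0.01 mg/kg. These two numbers lie within the usual scatter of each other, so compound 2 stands level with compound 1.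

Compound 3 (`CN1CCCN(C(=O)CCCOc2cc(C(=O)N3CCCCc4sccc43)ccc2NC(=O)c2ccccc2-c2ccccc2)CC1`) has not yet been measured. It differs from compound 2 in a single group: 4-methyl-1,4-diazepan-1-yl in place of 4-(diethylamino)piperidin-1-yl on a carbonyl carbon. Here 4-methyl-1,4-diazepan-1-yl stands in place of 4-(diethylamino)piperidin-1-yl on a carbonyl carbon.

For the measured compounds named here, no pair of measured compounds shows this exchange on its own, so the data give no direct guide to its size. The expectation therefore rests on the level set by compound 2 at 0.01 mg/kg. In this assay a small move towards a higher number is expected, close to the scatter, and no large loss is anticipated. The estimated change is a 2.0-fold higher number from compound 2 to compound 3 (0.30 log units; within the scatter). For compound 3 the expected value is 0.02 mg/kg, with an estimated range from 0.006 mg/kg to 0.08 mg/kg.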

Compound 3, dose for 50% inhibition: 0.008 mg/kg
Compound 3: the middle estimate sits 2.5-fold (0.40 log units) above what was measured; measured number inside the range.
By their numbers in this assay, from the lowest: compounds 3, 2 and 1 (each within the scatter of the next, the first and the last beyond it).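

In this assay, placing 4-methyl-1,4-diazepan-1-yl in place of 4-(diethylamino)piperidin-1-yl on a carbonyl carbon gives a 1.3-fold lower number from compound 2 to compound 3 (0.10 log units; within the scatter), so the two compounds stand level and this position accepts a seven-membered ring with two hetero atoms and fewer heavy atoms as well as the six-membered ring carrying diethylamino. For the compounds shown here, the other new step, a 2.5-fold lower number from compound 1 to compound 3 (0.40 log units; beyond the scatter), is the first gap in this short series to lie beyond the scatter, though only modestly, and it comes with 2-((4-methyl-1,4-diazepan-1-yl)carbonyl)ethyl in place of (4-(dimethylamino)piperidin-1-yl)carbonyl on a saturated chain carbon bound to an oxygen on an aromatic ring. Nothing at hand offers an explanation for either step.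

The compounds shown leave open whether a piperazine ring, an open-chain dimethylamino group or a carboxylic acid on this carbonyl carbon would also hold the level. They also leave open how that modest gap divides between the chain and the ring group, which change together in that step.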